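The source may report more compounds than this note shows. Statements on the series, on what has been measured and on what is new or still open speak of the compounds shown alone.

Of the compounds shown here, three have been measured in a functional assay on HT-29 cells (Homo sapiens) for cytotoxicity, read by MTT assay, with a stated time of 72 h; on this read-out higher numbers stand for weaker inhibition and lower numbers for stronger inhibition. Compound 1 `COc1cc2c(Oc3ccc(NC(=O)c4nn(-c5ccc([N+](=O)[O-])cc5)c(=O)c5ccccc45)cc3F)ccnc2cc1OCCCN1CCN(C)CC1` gives 2560 nM. Compound 2 `COc1cc2c(Oc3ccc(NC(=O)c4nn(-c5ccc(F)cc5)c(=O)c5ccccc45)cc3F)ccnc2cc1OCCCN1CCC(C)CC1` gives 330 nM, and compound 3 `COc1cc2c(Oc3ccc(NC(=O)c4nn(-c5ccccc5F)c(=O)c5ccccc45)cc3F)ccnc2cc1OCCCN1CCC(C)CC1` gives 510 nM. Compound 3 thus sits between the other two: its number and that of compound 2 lie within the usual scatter of each other, while the number of compound 1 is clearly higher, beyond the scatter.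

Among the measured compounds shown here, the only single-point step among the measured compounds, a 1.5-fold higher number from compound 2 to compound 3 (0.19 log units; within the scatter), moves a fluorine from one position of the phenyl ring to another and changes little.

Compound 4 `COc1cc2c(Oc3ccc(NC(=O)c4nn(-c5ccc([N+](=O)[O-])cc5)c(=O)c5ccccc45)cc3F)ccnc2cc1OCCCN1CCC(C)CC1` has not yet been measured. It differs from compound 3 in one place: 4-nitrophenyl in place of 2-fluorophenyl on an aromatic nitrogen. For the measured compounds named here, no measured step reports this exact exchange. The closest guide is compound 1, which also carries 4-nitrophenyl but differs from compound 4 in its side chain as well, so its higher number can only be read as a hint. On that basis the step is expected to raise the number, roughly a 2.4-fold higher number from compound 3 to compound 4 (0.37 log units; beyond the scatter), with wide uncertainty. For compound 4 the estimate in this assay is 1200 nM, with a range from 400 nM to 4000 nM.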

Compound 4, half-maximal inhibitory concentration: 2450 nM
For compound 4 the middle estimate is 2.0-fold (0.31 log units) below the measured one, within the range that was stated.
By their numbers in this assay, from the lowest: compounds 2 and 3 (each within the scatter of the next); then compounds 4 and 1 (each within the scatter of the next).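

With the side chain held constant, the group on the aromatic nitrogen clearly matters in this assay: 4-nitrophenyl in place of 2-fluorophenyl gives a 4.8-fold higher number from compound 3 to compound 4 (0.68 log units; beyond the scatter), and nitro in place of fluoro on the aromatic carbon gives a 7.4-fold higher number from compound 2 to compound 4 (0.87 log units; beyond the scatter), whereas the earlier move of fluorine around the ring stayed within the scatter. The side chain, by contrast, does not separate the two compounds that carry 4-nitrophenyl, since 4-methylpiperidin-1-yl in place of 4-methylpiperazin-1-yl gives a 1.0-fold lower number from compound 1 to compound 4 (0.02 log units; within the scatter), so among these compounds the high numbers go with 4-nitrophenyl and not with the side chain. No measurement at hand explains why the nitro group and the fluoro group differ in this way.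

The compounds shown leave open how an amine or a methoxy group in the place of the nitro group would read, and so whether the rise belongs to nitro alone. They also leave open whether 4-methylpiperazin-1-yl and 4-methylpiperidin-1-yl would remain indistinguishable with a fluorophenyl group on the aromatic nitrogen.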